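Adding a Second Fluorine to a Quinoline Sulfoxide Ester

The source may hold more compounds than are shown below. What is called first, only, known or untested is meant among the compounds shown, and "the series" means these compounds.

Measured compounds:
compound 1, `CCOC(=O)c1cc2c(CN3CCCC3)c(O)c(OC)cc2nc1C[S+]([O-])c1ccc(F)c(F)c1`, 16.5 uM
compound 2, `CCOC(=O)c1cc2c(CN3CCCC3)c(O)c(OC)cc2nc1C[S+]([O-])c1ccc(F)cc1`, 166 uM
compound 3, `CCOC(=O)c1cc2c(Cn3ccnc3)c(O)c(OC)cc2nc1C[S+]([O-])c1ccc(F)cc1`, 160 uM

All three were tested in an ADME assay on HepG2 2.2.15 cells (Homo sapiens) for cytotoxicity, read by MTT assay, with a stated time of 9 days; on this read-out lower numbers stand for higher toxicity in this test and higher numbers for lower toxicity in this test. Compound 2 and compound 3 share a common core except at one place, where the difference is 1H-imidazol-1-yl in place of pyrrolidin-1-yl on a saturated chain carbon bound to an aromatic carbon; in this assay the result is a 1.0-fold lower number from compound 2 to compound 3 (0.02 log units; within the scatter), so the two cores behave alike here.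

From compound 2 to compound 1 the change is fluoro in place of hydrogen on an aromatic carbon, and the step is a 10-fold lower number from compound 2 to compound 1 (1.00 log units; beyond the scatter). Compound 4, `CCOC(=O)c1cc2c(Cn3ccnc3)c(O)c(OC)cc2nc1C[S+]([O-])c1ccc(F)c(F)c1`, has not yet been measured; it differs from compound 3 by fluoro in place of hydrogen on an aromatic carbon, the same change at the same place, only on the core of compound 3 instead of the core of compound 2.

Since the two cores gave nearly the same number, the step is expected to carry over, so for compound 4 the expected step is an 8.9-fold lower number from compound 3 to compound 4 (0.95 log units; beyond the scatter), resting on the measured step from compound 2 to compound 1. Compound 4 is estimated at 18 uM, with a range of 7 uM to 50 uM.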

Compound 4, half-maximal toxic concentration: 90.8 uM
Compound 4: the middle estimate sits 5.0-fold (0.70 log units) below what was measured; measured number above the stated range.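

In this assay, adding the second fluoro group does not carry over evenly from one core to the other, as a 1.8-fold lower number from compound 3 to compound 4 (0.25 log units; within the scatter) is a much smaller step than the one seen on the pyrrolidin-1-yl core: the same change on two cores in this assay, a 10-fold lower number (1.00 log units; beyond the scatter) from compound 2 to compound 1 and a 1.8-fold lower number (0.25 log units; within the scatter) from compound 3 to compound 4, 5.7-fold (0.76 log units) apart, beyond the scatter of two such steps

Read the other way, putting 1H-imidazol-1-yl in place of pyrrolidin-1-yl changes nothing beyond the scatter on the 4-fluorophenyl compounds, yet with the 3,4-difluorophenyl group it gives a 5.5-fold higher number from compound 1 to compound 4 (0.74 log units; beyond the scatter): the same change on two cores in this assay, a 1.0-fold lower number (0.02 log units; within the scatter) from compound 2 to compound 3 and a 5.5-fold higher number (0.74 log units; beyond the scatter) from compound 1 to compound 4, 5.7-fold (0.76 log units) apart, beyond the scatter of two such steps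

So in this set of compounds the two changes do not act independently of each other, but four compounds cannot show why, and they say nothing about how the fluoro change would behave on any other core.

Going by these compounds, it remains open whether the large step seen with the 3,4-difluorophenyl group is tied to pyrrolidin-1-yl alone or would also appear with another amine, such as morpholine or dimethylamine. On these data alone, it is equally open whether a chloro group in place of the added fluoro would show the same difference between the two cores.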